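Aryl sulfonamides held at the limit: compound 2 to compound 4

The source may hold more compounds than are shown below. What is called first, only, known or untested is meant among the compounds shown, and "the series" means these compounds.

Measured compounds in a functional assay on KYSE-510 cells (Homo sapiens) for antiproliferative activity, read by crystal violet staining, with a stated time of 96 h; on this read-out lower numbers stand for stronger inhibition of growth and higher numbers for weaker inhibition of growth:
Compound 1 `O=S(=O)(NC1=NCCN1C(=S)SN1CCn2c1nsc2=S)c1ccc(C(F)(F)F)cc1` gives >= 20000 nM, a limit of this assay.
Compound 2 `COc1ccc(S(=O)(=O)NC2=NCCN2C(=S)SN2CCn3c2nsc3=S)cc1` gives >= 20000 nM, a limit of this assay.
Compound 3 `O=S(=O)(NC1=NCCN1C(=S)SN1CCn2c1nsc2=S)c1cccc(OC(F)(F)F)c1` gives >= 20000 nM, a limit of this assay.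

Compound 2 therefore stands only at a limit in this assay, and no number separates it from the other two. Going by the values given here, the one step between compounds that differ in a single place, a step that the two limits leave unreadable from compound 1 to compound 2, cannot be read because of the limit of >= 20000 nM in this assay, at which 3 of the 3 values shown sit.

Compound 4 `O=S(=O)(NC1=NCCN1C(=S)SN1CCn2c1nsc2=S)c1ccccc1Cl` has not yet been measured. It differs from compound 2 by 2-chlorophenyl in place of 4-methoxyphenyl on a sulfonyl sulfur. Among the compounds with values here, the only measured step on the aryl group is unreadable, and every value so far sits at the same limit, so nothing in the data points to a change of either sign for this exchange. The account expects compound 4 to remain at the limit as well, and any step that the limit leaves unreadable from compound 2 to compound 4 from compound 2 to compound 4 is expected to be unresolvable in this assay. The estimate for compound 4 is 30000 nM, with a range from 10000 nM to 100000 nM, most likely reported as a limit again.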

Compound 4, concentration for 50% growth inhibition: >= 20000 nM
Compound 4: a limit, no number (the forecaster's own chance of this, stated with the estimate: 85%); the middle value does not contradict the limit.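

Neither step into compound 4, from compound 1 or from compound 2, can be read in this assay, because all of these compounds stand at one limit and none has a number: the limit of >= 20000 nM in this assay, at which 4 of the 4 values shown sit. The compounds shown leave open whether exchanging the aryl group on the sulfonyl sulfur changes growth inhibition at all, and in which direction.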